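A few compounds are considered here, and "the series" means these few. Any claim that something is new, unique, unknown or untested is made for them only; others in the source may bear on it.

Notes on the sulfonamide series built on the shared core. Compound 1 `Cc1ccccc1S(=O)(=O)Nc1ccc(-c2nc3ccccc3o2)cc1` gives 85000 nM in an assay on cells for inhibition of HSP60/HSP10 (Homo sapiens), with a stated time of 60 min; a higher number here means a weaker inhibitor, a lower number a stronger inhibitor. Compound 3 `O=S(=O)(Nc1ccc(-c2nc3ccccc3o2)cc1)c1ccc(C(F)(F)F)cc1` gives 50000 nM in this assay. For compound 2 `CCc1ccc(S(=O)(=O)Nc2ccc(-c3nc4ccccc4o3)cc2)cc1` the result in this assay is > 100000 nM, which is a limit of the assay and not a number. Compound 2 therefore sits at the limit of > 100000 nM in this assay, at which 1 of the 3 values shown sits. The step of an at least 1.1-fold higher number from compound 1 to compound 2 (0.07 log units; that floor lies within the scatter) and the step of an at least 2.0-fold lower number from compound 2 to compound 3 (0.30 log units; that floor lies within the scatter) both rest on this limit, and neither reaches beyond the scatter. Compound 4 `CS(=O)(=O)Nc1ccc(-c2nc3ccccc3o2)cc1` is not yet measured. The change from compound 2 is methyl in place of 4-ethylphenyl on a sulfonyl sulfur. The two measured steps also vary the group on the sulfonyl sulfur and move nothing beyond the scatter, so in this assay no step beyond the scatter is expected here either, and no direction can be read from steps that start at a limit. Compound 4 is thus expected to give 100000 nM, within 30000 nM to 300000 nM. The expected step of a number no higher from compound 2 to compound 4 (the limit leaves the size open) stays within the scatter, and a limit rather than a number is considered likely.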

Compound 4, half-maximal inhibitory concentration: > 100000 nM
Compound 4 was reported as a limit; the forecaster's own chance of this, stated with the estimate: 55%; the middle value lies on the limit itself.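

Until now every group on the sulfonyl sulfur carried an aromatic ring; methyl shows the series without one at that place. In this assay compound 4 gives > 100000 nM, a limit of the assay and not a number, and it is the second compound of the series to sit there: the limit of > 100000 nM in this assay, at which 2 of the 4 values shown sit.

Among the compounds shown here, the step between the two limits, compound 2 and compound 4, cannot be read, and the one readable new step, an at least 1.1-fold higher number from compound 1 to compound 4 (0.07 log units; that floor lies within the scatter), shows no change beyond the scatter on going from 2-methylphenyl to methyl.

Still open, as far as these compounds go, is how a longer chain or an amine on the sulfonyl sulfur would read in this assay. Also open, from the compounds shown here alone, is whether a carboxylic acid on the aromatic ring at that place would give a number clear of the limit.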